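Swapping a Pyrazolyl for a Chloromethoxyphenyl on the Core

The source may report more compounds than this note shows. Statements on the series, on what has been measured and on what is new or still open speak of the compounds shown alone.

Compound 1 `Cc1nn(-c2nc(-c3ccc(Cl)c(Cl)c3)c(SC(C)C)s2)c(C(=O)O)c1-c1cnn(C)c1` gives 6800 nM.
Compound 2 `Cc1c(-c2cc(Cl)cc(Cl)c2)c(C(=O)O)nn1-c1nc(-c2cc(Cl)cc(Cl)c2)c(SC(C)C)s1` gives 2000 nM.

Both values come from a functional assay on BJAB cells (Homo sapiens) for antiproliferative activity, with a stated time of 4 days; on this read-out lower numbers stand for an effect already at smaller amounts and higher numbers for an effect only at larger amounts of compound. Compound 1 stands at the highest of the two numbers; its nearest neighbour, compound 2, sits at a lower number by a gap beyond the usual scatter. Compound 3 `COc1cc(Cl)cc(-c2c(C)nn(-c3nc(-c4ccc(Cl)c(Cl)c4)c(SC(C)C)s3)c2C(=O)O)c1` differs from compound 1 in one place: 3-chloro-5-methoxyphenyl in place of 1-methyl-1H-pyrazol-4-yl on an aromatic carbon. Within the data shown here, no measured pair isolates this change, so any expectation rests on compound 2 alone, whose lower value of 2000 nM hints that a change of this kind may help. For compound 3 a moderate step toward a lower number, a 2.7-fold lower number from compound 1 to compound 3 (0.43 log units; beyond the scatter), is expected, giving an estimated 2500 nM with a range of 800 nM to 8000 nM.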

Compound 3, half-maximal effective concentration: 760 nM
For compound 3 the middle estimate is 3.3-fold (0.52 log units) above the measured one; the whole stated range lies above it.
By their numbers in this assay, from the lowest: compound 3; then compound 2; then compound 1.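

In this assay the change to 3-chloro-5-methoxyphenyl brings an 8.9-fold lower number from compound 1 to compound 3 (0.95 log units; beyond the scatter) at this aromatic carbon next to the ring atom that bears a carboxy group. This position therefore responds to what it carries, and it accepts the larger, carbon-only six-membered ring with a clear gain on this read-out. Nothing available here explains the gain.

The compounds shown do not separate the part played by the chlorine from that of the methoxy group. Going by these compounds, how an amine or a longer alkyl chain on this carbon would behave also stays open.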